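A Second Methoxy Group Enters the Aryl Ring

This account rests on a few compounds, and the source may have more. Where it says the series, first, only, none or still open, it means among the compounds named here.

Three measured compounds share one core and differ only on the ring at the far end of the double bond. Compound 1 `Cc1nc(NC(=O)c2ccccc2)sc1C(=O)/C=C/c1ccccc1` gives 73.5% in an assay for inhibition of Polyunsaturated fatty acid 5-lipoxygenase (Homo sapiens), read by spectrophotometry, tested at 10 uM, in the presence of a further agent that is not named here; on this read-out higher numbers stand for more inhibition at the one concentration tested (going by the name of the read-out) and lower numbers for less inhibition. Compound 2 `Cc1nc(NC(=O)c2ccccc2)sc1C(=O)/C=C/c1ccc(F)cc1` gives 98% in this assay, and compound 3 `COc1ccc(/C=C/C(=O)c2sc(NC(=O)c3ccccc3)nc2C)cc1` gives 58.8% in this assay, the lowest of the three numbers; the steps of a number 14.7 percentage points lower from compound 1 to compound 3 (beyond the scatter) and a number 39.2 percentage points lower from compound 2 to compound 3 (beyond the scatter) both lie beyond the scatter.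

Compound 4 `COc1ccc(/C=C/C(=O)c2sc(NC(=O)c3ccccc3)nc2C)cc1OC` has not yet been measured. The change from compound 3 is methoxy in place of hydrogen on an aromatic carbon. Going by the values given here, one measured step bears on it directly: in a number 14.7 percentage points lower from compound 1 to compound 3 (beyond the scatter) a methoxy group entered the same ring and the number fell modestly, while a number 24.5 percentage points higher from compound 1 to compound 2 (beyond the scatter) shows that a different small group moved the number upward. Among the compounds with values here, no measured step adds a second methoxy group to a ring that already carries one, so the expectation rests on that single step. A modest lowering, or no change beyond the scatter, is expected: a number 10.8 percentage points lower from compound 3 to compound 4 (beyond the scatter). Compound 4 is therefore estimated at 48% in this assay, with a likely range from 30% to 66%.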

Compound 4, a percentage reported as inhibition, at one concentration (the size of the read-out at that concentration, not a potency): 70.2%
Beside the measured number, compound 4's estimate is 22.2 percentage points below it; measured number above the stated range.
By their numbers in this assay, from the lowest: compound 3; then compounds 4 and 1 (each within the scatter of the next); then compound 2.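

In this assay, a methoxy group placed ortho to a methoxy group raises the number (a number 11.4 percentage points higher from compound 3 to compound 4 (beyond the scatter)), whereas a methoxy group entering the unsubstituted ring lowered it (a number 14.7 percentage points lower from compound 1 to compound 3 (beyond the scatter)). The same change, methoxy in place of hydrogen on an aromatic carbon, therefore does not push the number in one fixed direction on this ring, and in these two steps its direction differs with what the ring already carries. Nothing available here explains this reversal.

On these data alone, it remains open whether the rise needs both methoxy groups or would also appear with the new methoxy group alone on the ring. As far as these compounds go, it is equally open whether a hydroxy group or a longer ethoxy chain in this place would move the number the same way.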